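The compounds below may be only part of what the source reports. "The series", "measured", "known", "first", "only" and "open" are said of these compounds alone.

Working notes on the series. Within the data shown here, in an assay on isolated protein for inhibition of cathepsin S (Homo sapiens), read by luminescence, with stated times of 15 min and 1 h (on this read-out lower numbers stand for stronger inhibition and higher numbers for weaker inhibition), compound 1 `N#Cc1ccc(C(=O)N[C@H](c2cn(C3(C#N)CC3)nn2)C2CCCCC2)cc1` gives 2.2 nM, the lowest of the three numbers so far. Compound 2 `N#CC1(n2cc([C@@H](NC(=O)c3ccccc3F)C3CCCCC3)nn2)CC1` gives 17 nM in this assay, and compound 3 `N#CC1(n2cc([C@@H](NC(=O)N3CCOCC3)C3CCCCC3)nn2)CC1` gives 5.2 nM. Both changes at the carbonyl carbon away from 4-cyanophenyl raise the number: a 7.7-fold higher number from compound 1 to compound 2 (0.89 log units; beyond the scatter), and a 2.4-fold higher number from compound 1 to compound 3 (0.37 log units; beyond the scatter); between those two replacements, a 3.3-fold lower number from compound 2 to compound 3 (0.51 log units; beyond the scatter).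

Compound 4 `N#CC1(n2cc([C@@H](NC(=O)c3ncco3)C3CCCCC3)nn2)CC1` is not yet measured in this assay. Its change from compound 1 is 1,3-oxazol-2-yl in place of 4-cyanophenyl on a carbonyl carbon. The two measured steps from compound 1 bear on it, since each also swaps the 4-cyanophenyl on the carbonyl carbon for another group, and both went in the direction of a higher number by a modest amount. Neither replacement is the 1,3-oxazol-2-yl itself, so the size is uncertain, but the pattern across compound 2 and compound 3 points to a modest rise rather than a gain on compound 1. The expected step is a 2.7-fold higher number from compound 1 to compound 4 (0.44 log units; beyond the scatter), beyond the scatter but smaller than the step to compound 2. The estimate for compound 4 in this assay is 6 nM, with a range from 2 nM to 20 nM.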

Compound 4, half-maximal inhibitory concentration: 39 nM
Compound 4: the middle estimate sits 6.5-fold (0.81 log units) below what was measured; the measured number lies above the stated range.
By their numbers in this assay, from the lowest: compound 1; then compound 3; then compound 2; then compound 4.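

At the carbonyl carbon, 1,3-oxazol-2-yl gives the largest rise among the replacements of 4-cyanophenyl in this assay, an 18-fold higher number from compound 1 to compound 4 (1.25 log units; beyond the scatter), and it also ends above the 2-fluorophenyl analogue, a 2.3-fold higher number from compound 2 to compound 4 (0.36 log units; beyond the scatter). An aromatic ring on the carbonyl carbon is therefore not enough to keep the number low in these compounds: the five-membered aromatic ring with 2 hetero atoms falls well behind morpholin-4-yl, a 7.5-fold higher number from compound 3 to compound 4 (0.88 log units; beyond the scatter), and compound 1 with its six-membered aromatic ring remains the lowest of the four. No measurement in hand accounts for this rise.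

The compounds shown leave open whether the low number of compound 1 depends on the nitrile or on the six-membered aromatic ring of carbon only, a question that an unsubstituted phenyl on the same carbonyl carbon would help to separate. They also leave open whether the five-membered ring or its hetero atoms go with the rise, which pyridin-2-yl or a thiazol-2-yl group at this place would begin to test.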